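Methyl to Methoxy at Two Places on the Shared Core

A few compounds are considered here, and "the series" means these few. Any claim that something is new, unique, unknown or untested is made for them only; others in the source may bear on it.

Compound 1, `Cc1cccc2cc(-c3ccc(Br)nn3)c(=O)oc12`, gives 2640 nM in an assay on cells for inhibition of Amine oxidase [flavin-containing] B (Homo sapiens), read by fluorescence and Amplex Red, with a stated time of 15 min; on this read-out lower numbers stand for stronger inhibition and higher numbers for weaker inhibition.
Compound 2, `COc1cccc2cc(-c3ccc(Br)nn3)c(=O)oc12`, gives 12900 nM in this assay.
Compound 3, `COc1ccc(-c2cc3cc(C)ccc3oc2=O)nn1`, gives 17600 nM in this assay.

The change from compound 1 to compound 2 is methoxy in place of methyl on an aromatic carbon and it gave a 4.9-fold higher number from compound 1 to compound 2 (0.69 log units; beyond the scatter). The difference between the cores of compound 1 and compound 3 is not broken down here. Compound 4, `COc1ccc2oc(=O)c(-c3ccc(OC)nn3)cc2c1`, is not yet measured; it arises from compound 3 by methoxy in place of methyl on an aromatic carbon. This is the same kind of change, but the place differs: in compound 2 the methoxy sits ortho to a fused ring and meta to a fused ring, in compound 4 meta to a fused ring and para to a fused ring. Among the measured compounds shown here, the step of a 4.9-fold higher number from compound 1 to compound 2 (0.69 log units; beyond the scatter) is the only guide; the place differs, so its size is held loosely. A higher number is expected for compound 4, estimated as a 2.6-fold higher number from compound 3 to compound 4 (0.41 log units; beyond the scatter). Compound 4 is thus expected to give 45000 nM in this assay, between 15000 nM and 150000 nM.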

Compound 4, half-maximal inhibitory concentration: 11100 nM
Beside the measured number, compound 4's estimate is 4.1-fold (0.61 log units) above it, outside the stated range (below it).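

In this assay, methoxy in place of methyl gave a 1.6-fold lower number from compound 3 to compound 4 (0.20 log units; within the scatter), so on this core the change does not register beyond the scatter. The change therefore did not carry over in size from one core to the other: the same change on two cores in this assay, a 4.9-fold higher number (0.69 log units; beyond the scatter) from compound 1 to compound 2 and a 1.6-fold lower number (0.20 log units; within the scatter) from compound 3 to compound 4, 7.7-fold (0.89 log units) apart, beyond the scatter of two such steps. The two pairs differ both in the place of the methoxy and in the rest of the core, and these two steps alone do not show which of the two accounts for the gap.

From the compounds shown here alone, it remains open whether the change would give matching steps if made at the same place on both cores. Also open, going by these compounds, is how an amine, a carboxylic acid or a longer chain such as ethyl would read at these places.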